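This account rests on a few compounds, and the source may have more. Where it says the series, first, only, none or still open, it means among the compounds named here.

Measured in an ADME assay on microsomes from liver (Mus musculus, strain CD-1) for metabolic stability, read by LC-MS, with a stated time of 60 min, tested at 20 uM; on this read-out lower numbers stand for a shorter-lived compound and higher numbers for a longer-lived compound:
Compound 1 `CC(Sc1nc2nn(CC3COC3)cc2c(=O)n1-c1ccccc1)c1ccccc1` gives 0.317 h
Compound 2 `CC(Sc1nc2nn(C3COC3)cc2c(=O)n1-c1ccccc1)c1ccccn1` gives > 1 h (a limit of the assay)
Compound 3 `CC(Sc1nc2nn(C3COC3)cc2c(=O)n1-c1ccccc1)c1ccccc1` gives 0.783 h

Among the measured compounds shown here, of the two actual numbers, the one for compound 3 is the higher. Compound 4 `CC(Sc1nc2nn(C3(C)COC3)cc2c(=O)n1-c1ccccc1)c1ccccc1` has methyl in place of hydrogen on a saturated ring carbon, so that oxetan-3-yl becomes 3-methyloxetan-3-yl (methyl in place of hydrogen on a saturated ring carbon). The nearest evidence is the modest change to oxetan-3-yl from (oxetan-3-yl)methyl on an aromatic nitrogen (a 2.5-fold higher number from compound 1 to compound 3 (0.39 log units; beyond the scatter)). The phenyl for pyridin-2-yl change (an at least 1.2-fold lower number from compound 2 to compound 3 (0.10 log units; that floor lies within the scatter)) has a floor within the scatter and concerns another group. Neither step adds this methyl, so no shift beyond the scatter is expected in this assay (a 1.0-fold higher number from compound 3 to compound 4 (0.01 log units; within the scatter)). Compound 4 is estimated at 0.8 h (expected range 0.4 h to 1.6 h).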

Compound 4, half-life: > 1 h
Compound 4: only a limit was reported; the forecaster's own chance of this, stated with the estimate: 30%; middle value at least 1.2-fold (0.09 log units) from the limit.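

In this assay compound 4 gives a limit of the assay rather than a number, the second such limit among these compounds: the limit of > 1 h in this assay, at which 2 of the 4 values shown sit. With 3-methyloxetan-3-yl in place of oxetan-3-yl, the read-out shows an at least 1.2-fold higher number from compound 3 to compound 4 (0.10 log units; that floor lies within the scatter), so this saturated ring carbon accepts a methyl with no loss of half-life, though the floor alone shows no gain. Against (oxetan-3-yl)methyl, the change is clearer: an at least 3.1-fold higher number from compound 1 to compound 4 (0.49 log units; beyond the scatter).

As far as these compounds go, the true size of the methyl step remains open. So does whether an ethyl group or an amine on the same ring carbon would read the same way.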